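The source may report more compounds than this note shows. Statements on the series, on what has been measured and on what is new or still open speak of the compounds shown alone.

Measured so far in a functional assay on A549 cells (Homo sapiens) for antiproliferative activity, read by MTT assay, with a stated time of 72 h, in the presence of a further agent that is not named here; on this read-out higher numbers stand for weaker inhibition and lower numbers for stronger inhibition:
- compound 1 `Nc1nc2[nH]c(CCSCC(=O)NCc3cccnc3)cc2c(=O)[nH]1` gives 56600 nM here
- compound 2 `Nc1nc2[nH]c(CCSCCC(=O)NCc3ccncc3)cc2c(=O)[nH]1` gives 7870 nM here

Compound 1 holds the higher of these two numbers, so it is the weaker inhibitor of the pair, and the gap lies beyond the usual scatter. Compound 3 `Nc1nc2[nH]c(CCSCC(=O)NCc3ccncc3)cc2c(=O)[nH]1` differs from compound 1 by pyridin-4-yl in place of pyridin-3-yl on a saturated chain carbon bound to an amide-type nitrogen and has the same atoms, joined differently. Put simply, pyridin-4-yl stands in place of pyridin-3-yl on a saturated chain carbon bound to an amide-type nitrogen. Among the measured compounds shown here, no measured pair shows this change alone. Compound 2 also carries pyridin-4-yl but has a different chain, and its 7870 nM gives only a loose hint of a lower number. A moderate drop is therefore expected, with the estimated step being a 2.6-fold lower number from compound 1 to compound 3 (0.41 log units; beyond the scatter) in this assay. For compound 3 the estimated value is 22000 nM, with an expected range from 7000 nM to 60000 nM.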

Compound 3, half-maximal inhibitory concentration: 42400 nM
The estimate for compound 3 lay 1.9-fold (0.28 log units) below the measured number, within the range that was stated.
By their numbers in this assay, from the lowest: compound 2; then compounds 3 and 1 (each within the scatter of the next).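

In this assay, the swap of pyridin-3-yl for pyridin-4-yl on a saturated chain carbon bound to an amide-type nitrogen gives a 1.3-fold lower number from compound 1 to compound 3 (0.13 log units; within the scatter) and so cannot be told apart from repeat-measurement scatter. Pyridin-4-yl alone therefore does not account for the number of compound 2 at 7870 nM in this series, as compound 3 carries the same group and gives 42400 nM with a different chain. Nothing measured here offers a reason for this result.

On these data alone, it remains open whether the longer chain of compound 2 would give a similar number with pyridin-3-yl in place of pyridin-4-yl. As far as these compounds go, it is also open whether pyridin-2-yl or a plain phenyl ring on this carbon would shift the number beyond the scatter.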